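Urea-linked pyrimidine analogues tested on NCI-H226 cells

The source may report more compounds than this note shows. Statements on the series, on what has been measured and on what is new or still open speak of the compounds shown alone.

Three compounds sharing one core were measured in a functional assay on NCI-H226 cells (Homo sapiens) for inhibition, read by MTT assay, with a stated time of 48 h, tested at 10 uM; on this read-out higher numbers stand for more inhibition at the one concentration tested (going by the name of the read-out) and lower numbers for less inhibition. Compound 1 `CCc1ccc(Nc2cc(NC(=O)Nc3cc(OC)cc(OC)c3)ncn2)cc1` gives 50.1%. Compound 2 `COc1cc(NC(=O)Nc2cc(Nc3ccc(F)c(Cl)c3)ncn2)cc(OC)c1` gives 36.7%. Compound 3 `O=C(Nc1cc(Nc2ccc(F)c(Cl)c2)ncn1)Nc1c(Cl)cccc1Cl` gives 47.3%.

Compound 2 and compound 1 differ in a single place: 4-ethylphenyl in place of 3-chloro-4-fluorophenyl on a nitrogen on an aromatic ring. This change brought a number 13.4 percentage points higher from compound 2 to compound 1 (beyond the scatter). Compound 2 and compound 3 share the same group on the nitrogen on the aromatic ring but differ elsewhere; the difference between their two cores is not broken down here. The values of compound 3 and compound 1 lie close to one another, and the gap between them is within the usual scatter, so nothing can be said of their order.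

Compound 4 `CCc1ccc(Nc2cc(NC(=O)Nc3c(Cl)cccc3Cl)ncn2)cc1` has not yet been measured in this assay. It differs from compound 3 in one place: 4-ethylphenyl in place of 3-chloro-4-fluorophenyl on a nitrogen on an aromatic ring. For the measured compounds named here, this is the same change as the one from compound 2 to compound 1, made at the same kind of position on the core of compound 3. It is expected that compound 4 will show a number 10.7 percentage points higher from compound 3 to compound 4 (beyond the scatter), a step judged beside a number 13.4 percentage points higher from compound 2 to compound 1 (beyond the scatter), with the expectation resting on the value of compound 3 47.3% as the starting point. Compound 4 is therefore estimated to give 58%, with an expected range from 42% to 72%.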

Compound 4, a percentage reported as inhibition, at one concentration (the size of the read-out at that concentration, not a potency): 39.5%
Compound 4: middle estimate off by 18.5 percentage points, on the high side; measured number below the stated range.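

In this assay, for the compounds shown here, placing 4-ethylphenyl where 3-chloro-4-fluorophenyl stood, on a nitrogen on an aromatic ring, gave a number 7.8 percentage points lower from compound 3 to compound 4 (within the scatter), so on this core the change produced no step that can be told apart from the scatter. The gain seen on the other core therefore did not carry over, and the two steps differ by more than repeated measurement would explain: the same change on two cores in this assay, a number 13.4 percentage points higher (beyond the scatter) from compound 2 to compound 1 and a number 7.8 percentage points lower (within the scatter) from compound 3 to compound 4, 21.2 percentage points apart, beyond the scatter of two such steps

This shows that, across these two pairs, the outcome of the change depends on the core that carries it, so a step taken from one core is a poor guide to the other; it does not show which feature of the two cores is responsible, how the change would behave on a third core, or how potency would compare, as each number comes from a single concentration.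

The compounds shown leave open whether the dependence on the core would persist with other groups on the urea, such as a simple phenyl or a morpholine-bearing phenyl. They also leave open how a smaller or longer group on the aniline ring, such as a methyl, a butyl chain or a carboxylic acid, would fare on each core.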